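A few compounds are considered here, and "the series" means these few. Any claim that something is new, unique, unknown or untested is made for them only; others in the source may bear on it.

Measured so far in a functional assay on PC-3 cells (Homo sapiens) for cytotoxicity, read by MTT assay, with a stated time of 72 h; on this read-out higher numbers stand for weaker inhibition and lower numbers for stronger inhibition: compound 3 `Cc1ccc(Nc2nc(SCc3ccc(C(F)(F)F)cc3)nc3ccccc23)cc1` at 21100 nM; compound 1 `FC(F)(F)c1ccc(CSc2nc(Nc3cccc(C(F)(F)F)c3)c3ccccc3n2)cc1` at 12900 nM; compound 2 `FC(F)(F)c1ccc(CSc2nc(Nc3ccc(Cl)cc3)c3ccccc3n2)cc1` at 7110 nM.

Compound 3 has the highest number of the three, though its gap to compound 1 lies within the scatter (a 1.6-fold higher number from compound 1 to compound 3 (0.21 log units; within the scatter)), while the gap to compound 2 lies beyond it (a 3.0-fold higher number from compound 2 to compound 3 (0.47 log units; beyond the scatter)). Compound 4 `Fc1ccc(Nc2nc(SCc3ccc(C(F)(F)F)cc3)nc3ccccc23)cc1Cl` differs from compound 3 by 3-chloro-4-fluorophenyl in place of 4-methylphenyl on a nitrogen on an aromatic ring. The step that bears on it most directly is a 3.0-fold higher number from compound 2 to compound 3 (0.47 log units; beyond the scatter), read the other way: a chloro on the anilino ring gave a lower number than methyl. The step of a 1.8-fold lower number from compound 1 to compound 2 (0.26 log units; within the scatter) stayed within the scatter. A modest move downward, toward compound 2, is therefore expected in this assay, as a 2.8-fold lower number from compound 3 to compound 4 (0.45 log units; beyond the scatter). Compound 4 is estimated at 7500 nM, within 3500 nM to 16000 nM.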

Compound 4, half-maximal inhibitory concentration: 18600 nM
Beside the measured number, compound 4's estimate is 2.5-fold (0.39 log units) below it; the measured number lies above the stated range.
By their numbers in this assay, from the lowest: compounds 2, 1, 4 and 3 (each within the scatter of the next, the first and the last beyond it).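

In this assay, a chloro on the ring at this nitrogen does not by itself go with the lower number: 3-chloro-4-fluorophenyl stays level with 4-methylphenyl (a 1.1-fold lower number from compound 3 to compound 4 (0.05 log units; within the scatter)) and with 3-(trifluoromethyl)phenyl (a 1.4-fold higher number from compound 1 to compound 4 (0.16 log units; within the scatter)), while 4-chlorophenyl stands apart (a 2.6-fold higher number from compound 2 to compound 4 (0.42 log units; beyond the scatter)). Only 4-chlorophenyl now separates from any other group here, and only from 4-methylphenyl and 3-chloro-4-fluorophenyl. No measurement at hand accounts for the gap between the two chloro-bearing groups.

Open, on these data alone, is whether an amine or a carboxylic acid on this ring would shift the number beyond the scatter.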